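Methoxy to Hydroxy on Compound 2

This account rests on a few compounds, and the source may have more. Where it says the series, first, only, none or still open, it means among the compounds named here.

In an ADME assay on HEK293 cells (Homo sapiens) for cytotoxicity, read by MTT assay, with a stated time of 72 h (a higher number here means a weaker inhibitor, a lower number a stronger inhibitor), compound 1 `COc1ccc(C2=C(c3cc(OC)c(OC)c(OC)c3)C(=O)C(OC(C)=O)C2)cc1F` gives 59 ug/mL. Compound 2 `COc1ccc(C2=C(c3cc(OC)c(OC)c(OC)c3)C(=O)CC2O[SiH2]C(C)(C)C)cc1OC` reads > 100 ug/mL, which is a limit of the assay and not a number. Compound 3 `COc1ccc(C2=C(c3cc(OC)c(OC)c(OC)c3)C(=O)CC2O[SiH2]C(C)(C)C)cc1O` differs from compound 2 in one place, hydrogen in place of methyl on an oxygen on an aromatic ring, so methoxy becomes hydroxy. Within the data shown here, no measured pair here tests this change, so the expectation is loose. A modest step toward stronger inhibition is expected, an at least 1.4-fold lower number from compound 2 to compound 3 (0.15 log units; that floor lies within the scatter). For compound 3, the estimated value is 70 ug/mL, within an expected range of 25 ug/mL to 150 ug/mL.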

Compound 3, half-maximal inhibitory concentration: 42 ug/mL
Compound 3: the middle estimate sits 1.7-fold (0.22 log units) above what was measured, within the range that was stated.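

In this assay, swapping methoxy for hydroxy on the aromatic ring gives an at least 2.3-fold lower number from compound 2 to compound 3 (0.37 log units; beyond the scatter), the first sign that this oxygen substituent affects the read-out. The earlier compounds shown here offered no pair that tested this position. The step is a floor and not an exact size, because compound 2 stands at a limit of the assay: the limit of > 100 ug/mL in this assay, at which 1 of the 3 values shown sits.

Among these compounds, only this single pair tests the change, and it is not known whether the same swap would act alike on another core. Going by these compounds, how an amine or an ethoxy group at this place would read also remains open.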